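The source may report more compounds than this note shows. Statements on the series, on what has been measured and on what is new or still open speak of the compounds shown alone.

Measured to date in this series:

compound 1, `O=C(Nc1cccc(-n2cc(-c3ccncc3)c(-c3ccc(Cl)c(O)c3)n2)c1)Nc1ccc(Cl)c(Cl)c1` — 8970 nM
compound 2, `COc1cc(-c2nn(-c3cccc(NC(=O)c4ccc(Cl)c(C(F)(F)F)c4)c3)cc2-c2ccncc2)ccc1Cl` — 20300 nM
compound 3, `O=C(Nc1cccc(-n2cc(-c3ccncc3)c(-c3ccc(Cl)c(O)c3)n2)c1)Nc1cc(C(F)(F)F)cc(C(F)(F)F)c1` — 1490 nM

All three numbers come from a functional assay on SF-539 cells (Homo sapiens) for inhibition, read by sulforhodamine B assay, with a stated time of 48 h; a lower number here means a stronger inhibitor of growth, a higher number a weaker inhibitor of growth. Compound 2 gives the highest of the three values in this assay; compound 1 sits nearest to it, at a gap recorded as beyond the scatter, and compound 3 lies furthest from it, also beyond the scatter. Compound 2 therefore marks the weak end of what has been measured so far.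

The next compound, compound 4, `COc1cc(-c2nn(-c3cccc(NC(=O)Nc4cccc(C(F)(F)F)c4)c3)cc2-c2ccncc2)ccc1Cl`, is not yet measured in this assay. It differs from compound 2 in one place: (3-(trifluoromethyl)phenyl)amino in place of 4-chloro-3-(trifluoromethyl)phenyl on a carbonyl carbon. The group that enters brings one hydrogen-bond donor where the leaving group had none; the count of heavy atoms and of aromatic rings does not change.

Going by the values given here, no step between two measured compounds repeats this change, so the expectation for compound 4 rests on the spread of the three values alone. Compounds 1 and 3 both give lower numbers than compound 2, so the step from compound 2 to compound 4 is expected to run downward, at a size of about a 3.4-fold lower number from compound 2 to compound 4 (0.53 log units; beyond the scatter), modest rather than large. Compound 4 is thus estimated at 6000 nM in this assay, with a range from 1800 nM to 18000 nM.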

Compound 4, concentration for total growth inhibition: 2420 nM
For compound 4 the middle estimate is 2.5-fold (0.39 log units) above the measured one, and the stated range covers the measured number.
By their numbers in this assay, from the lowest: compounds 3 and 4 (each within the scatter of the next); then compound 1; then compound 2.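

In this assay, going by these compounds alone, (3-(trifluoromethyl)phenyl)amino in place of 4-chloro-3-(trifluoromethyl)phenyl on the carbonyl carbon gives an 8.4-fold lower number from compound 2 to compound 4 (0.92 log units; beyond the scatter), the first step that can be read on a single change. The position therefore responds to a change of group, even though the heavy-atom count and the aromatic ring count stay the same and the entering group adds one hydrogen-bond donor. No measurement shown bears on the reason for this step.

This one step changes two things at once, adding the amino nitrogen and removing the chlorine, and the compounds shown do not separate the two, so the share of each in the step remains open. Also open is how the same carbonyl position would respond to a group of another kind, such as a cyclohexyl ring, a piperidine amine or a carboxylic acid on the aromatic ring, since every group shown there carries a halogenated or trifluoromethyl-bearing phenyl ring.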